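Swapping Dimethylamino for Piperidinyl on the Amine Chain

The source may hold more compounds than are shown below. What is called first, only, known or untested is meant among the compounds shown, and "the series" means these compounds.

Compound 1 `Cc1cc(NCCN(C)C)nc2ccc(NC(=O)c3ccc(Cl)c(Cl)c3)cc12` was tested in a functional assay on MCF7 cells (Homo sapiens) for antiproliferative activity, read by MTT assay, with a stated time of 72 h (on this read-out lower numbers stand for stronger inhibition and higher numbers for weaker inhibition), where compound 1 gives 2550 nM. Within the data shown here, the only other measured compound is compound 2 `CCN1CCN(c2cc(C)c3cc(NC(=O)c4ccc(Cl)cc4)ccc3n2)CC1`; in this assay compound 2 gives 1530 nM. Compound 1 has the higher of the two numbers, yet its gap to compound 2 lies within the scatter, so the pair cannot be told apart. Compound 3 `Cc1cc(NCCN2CCCCC2)nc2ccc(NC(=O)c3ccc(Cl)c(Cl)c3)cc12` differs from compound 1 in one place: piperidin-1-yl in place of dimethylamino on a saturated chain carbon, two bonds along the chain from a nitrogen on an aromatic ring. Among the measured compounds shown here, no measured pair shows this change, so in this assay only a small step, a 1.3-fold lower number from compound 1 to compound 3 (0.11 log units; within the scatter), is expected, with no clear direction beyond the scatter. Compound 3 is estimated at 2000 nM, within 700 nM to 6000 nM.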

Compound 3, half-maximal inhibitory concentration in the MCF7 assay: 1190 nM
Beside the measured number, compound 3's estimate is 1.7-fold (0.23 log units) above it; measured number inside the range.
By their numbers in the MCF7 assay, from the lowest: compounds 3, 2 and 1 (each within the scatter of the next, the first and the last beyond it).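

Among these compounds, in the MCF7 assay, piperidin-1-yl in place of dimethylamino gives the first step that lies beyond the scatter, a 2.1-fold lower number from compound 1 to compound 3 (0.33 log units; beyond the scatter), so the end of this chain can modestly affect the read-out. In a physicochemical assay for solubility (a lower number here means a less soluble compound, a higher number a more soluble compound), compound 1 gives 122 ug/mL and compound 3 gives 70.8 ug/mL, a gap within the scatter, so the two cannot be told apart on solubility. Nothing at hand explains the step in antiproliferative activity. Still open, going by these compounds, is how pyrrolidin-1-yl or morpholin-4-yl in this place, or a longer chain, would compare in either read-out.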